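A few compounds are considered here, and "the series" means these few. Any claim that something is new, unique, unknown or untested is made for them only; others in the source may bear on it.

In a physicochemical assay for solubility, at pH 7.5 (on this read-out higher numbers stand for higher solubility and lower numbers for lower solubility), compound 1 `CCOC(=O)Nc1ccc(Oc2ccc(NC(=O)Nc3cc(C(C)(C)C)nn3C)cc2)cc1` gives 95 ug/mL and compound 2 `Cn1nc(C(C)(C)C)cc1NC(=O)Nc1ccc(Sc2ccncc2)cc1` gives 655 ug/mL, the higher of the two numbers, with a gap beyond the scatter. Compound 3 `Cn1nc(C(C)(C)C)cc1NC(=O)Nc1ccc(CSc2ccncc2)cc1` departs from compound 2 in one place: ((pyridin-4-yl)sulfanyl)methyl in place of (pyridin-4-yl)sulfanyl on an aromatic carbon, with ((pyridin-4-yl)sulfanyl)methyl in place of (pyridin-4-yl)sulfanyl on an aromatic carbon. Within the data shown here, no measured pair shows this kind of change, so the expectation starts from compound 2 at 655 ug/mL. The expected step, a 1.9-fold lower number from compound 2 to compound 3 (0.27 log units; within the scatter), is a small fall within the scatter. For compound 3 the estimated value is 350 ug/mL, with an expected range of 120 ug/mL to 900 ug/mL.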

Compound 3, solubility: 322 ug/mL
Beside the measured number, compound 3's estimate is 1.1-fold (0.04 log units) above it; low and high end bracket the measured number.
By their numbers in this assay, from the lowest: compound 1; then compound 3; then compound 2.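

In this assay, among these compounds, the first one-place change at this position, on an aromatic carbon para to a large group, gives a 2.0-fold lower number from compound 2 to compound 3 (0.31 log units; beyond the scatter). The change adds one carbon and leaves the counts of donors and acceptors and the pyridine ring as they were, so even this small extension moves the number by a modest step. No measurement shown accounts for this step.

As far as these compounds go, whether a longer chain at this position lowers the number further remains open. So does whether an amine there would shift it in the opposite direction.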